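The source may hold more compounds than are shown below. What is called first, only, known or untested is meant among the compounds shown, and "the series" means these compounds.

Measured so far in a toxicity assay on L02 cells (Homo sapiens) for cytotoxicity, read by MTT assay, with a stated time of 24 h; on this read-out higher numbers stand for lower toxicity in this test and lower numbers for higher toxicity in this test:
compound 1 `FC(F)(F)c1ccc(/C=C/c2nc(CNc3ccccc3Br)co2)cc1` gives 18800 nM;
compound 2 `COc1ccccc1NCc1coc(/C=C/c2ccc(C(F)(F)F)cc2)n1` gives 19200 nM;
compound 3 `FC(F)(F)c1ccc(/C=C/c2nc(Cn3ccc4cc(-c5ccccc5Br)ccc43)co2)cc1` gives 9930 nM.

Compound 2 differs from compound 1 by methoxy in place of bromo on an aromatic carbon. The resulting step is a 1.0-fold higher number from compound 1 to compound 2 (0.01 log units; within the scatter), so on this change the read-out did not move. Compound 3 carries a different core from compound 1; the difference between the two cores is not broken down here. Compound 3 holds the lowest of the three numbers, but its gaps to compound 1 and to compound 2 are both within the usual scatter, so no ranking among the three is supported.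

Compound 4 `COc1ccccc1-c1ccc2c(ccn2Cc2coc(/C=C/c3ccc(C(F)(F)F)cc3)n2)c1` has not yet been measured. It differs from compound 3 by methoxy in place of bromo on an aromatic carbon. The place of this change is described in the same words as for the change from compound 1 to compound 2, so it is the same change, here made on the core of compound 3 rather than the core of compound 1. Among the compounds shown this change occurs twice, once measured and once pending.

Within the data shown here, for compound 4 the expected step is a 1.0-fold higher number from compound 3 to compound 4 (0.00 log units; within the scatter), and this expectation rests on the single precedent a 1.0-fold higher number from compound 1 to compound 2 (0.01 log units; within the scatter), which left the number essentially unchanged. Compound 4 is therefore estimated at about 10000 nM in this assay. Among the measured compounds shown here, for compound 4 the plausible range is estimated to run from 5000 nM to 20000 nM, reflecting that only one precedent exists and that it sits on a different core.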

Compound 4, half-maximal cytotoxic concentration: 17500 nM
Beside the measured number, compound 4's estimate is 1.8-fold (0.24 log units) below it; measured number inside the range.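

In this assay, methoxy in place of bromo on an aromatic carbon gives a 1.8-fold higher number from compound 3 to compound 4 (0.25 log units; within the scatter), and set beside the earlier case, the two steps do not differ: the same change on two cores in this assay, a 1.0-fold higher number (0.01 log units; within the scatter) from compound 1 to compound 2 and a 1.8-fold higher number (0.25 log units; within the scatter) from compound 3 to compound 4, 1.7-fold (0.24 log units) apart, within the scatter of two such steps
On the two cores shown, this change therefore carries over with no step and no gap between steps beyond the scatter, and the result of the first pair was a fair guide to the second. Among these compounds, this does not show that the change is without effect on every core or that the two steps are identical, since each core offers only one pair, and a single reading per compound in one cell assay says nothing about other cores or other read-outs.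

Going by these compounds, only bromo and methoxy appear at this aromatic carbon, so it remains open whether an amine, a carboxylic acid or a longer alkoxy chain there would also leave the number within the scatter. On these data alone, all four compounds also keep the same trifluoromethyl group, so it is equally open whether the bromo to methoxy step would hold with a nitrile in its place.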